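The source may hold more compounds than are shown below. What is called first, only, known or untested is meant among the compounds shown, and "the series" means these compounds.

Working notes on the series in a functional assay on the whole organism (strain albino) for inhibition, with Rattus norvegicus as the target, read by paw edema, with stated times of 1 h and 3 h, at a dose of 100 mg/kg by the oral route; on this read-out lower numbers stand for a weaker effect and higher numbers for a stronger effect at the one dose given.

Of the compounds shown here, three sharing one core have been measured. Compound 1 `N#Cc1c(-c2ccc(O)cc2)nc(SCC(=O)Nn2c(COc3ccc(Cl)cc3Cl)nc3ccccc3c2=O)[nH]c1=O` gives 68.4%. Compound 2 `O=C(CSc1nc(-c2ccccc2)c(C(=O)O)c(=O)[nH]1)Nn1c(COc2ccc(Cl)cc2Cl)nc2ccccc2c1=O` gives 64.9%. Compound 3 `N#Cc1c(Cl)nc(SCC(=O)Nn2c(COc3ccc(Cl)cc3Cl)nc3ccccc3c2=O)nc1-c1ccccc1` gives 68.4%. In this assay compound 3 is level with compound 1 at the digits recorded, and together they hold the highest of the three numbers; compound 2 sits within the usual scatter of both, so no order among the three can be read from these values. Going by the values given here, no pair of measured compounds differs in only one place, so no single-point step is available.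

Compound 4 `N#Cc1c(Cl)nc(SCC(=O)Nn2c(COc3ccc(Cl)cc3Cl)nc3ccccc3c2=O)nc1-c1ccc(O)cc1` is not yet measured. It differs from compound 3 by hydroxy in place of hydrogen on an aromatic carbon. No comparison among the measured compounds isolates this change, so the expectation rests on compound 3 alone, with compound 1 giving 68.4% as the only other carrier of a hydroxy on that ring. The step from compound 3 to compound 4 is expected to be a number 0.4 percentage points lower from compound 3 to compound 4 (within the scatter), that is, no change beyond the scatter. For compound 4 in this assay the estimated value is 68%, between 58% and 78%.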

Compound 4, a percentage reported as inhibition, in the whole organism at one dose (the size of the read-out at that dose, not a potency): 73.7%
Beside the measured number, compound 4's estimate is 5.7 percentage points below it; low and high end bracket the measured number.
By their numbers in this assay, from the lowest: compounds 2, 1, 3 and 4 (each within the scatter of the next).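

Going by these compounds alone, the first single-point reading in this assay is phenyl to 4-hydroxyphenyl on the shared core, which gives a number 5.3 percentage points higher from compound 3 to compound 4 (within the scatter) and shows that this aromatic carbon, para to a large group, carries a hydroxy with no difference beyond the scatter. The reading rests on this one pair, so it supports no order between the two compounds and no general rule for the series. Nothing available bears on the size of this step.

The compounds shown leave open how an amine, a methoxy or a carboxylic acid on this same aromatic carbon would read in this assay at the one dose given. They also leave open whether the hydroxy step would read the same on the cores of compound 1 and compound 2.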